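A few compounds are considered here, and "the series" means these few. Any claim that something is new, unique, unknown or untested is made for them only; others in the source may bear on it.

Of the compounds shown here, three built on one shared core have been measured in a functional assay on SN12C cells (Homo sapiens) for inhibition, read by sulforhodamine B assay, with a stated time of 48 h; on this read-out lower numbers stand for stronger inhibition of growth and higher numbers for weaker inhibition of growth. Compound 1 `O=C(Nc1cccc(-n2cc(-c3ccncc3)c(-c3ccc(Cl)c(O)c3)n2)c1)Nc1cccc(C(F)(F)F)c1` gives 2010 nM, compound 2 `O=C(Nc1cccc(-n2cc(-c3ccncc3)c(-c3ccc(Cl)c(O)c3)n2)c1)Nc1ccc(Cl)c(Cl)c1` gives 1310 nM, and compound 3 `COc1cc(-c2nn(-c3cccc(NC(=O)Nc4ccc(Cl)c(C(F)(F)F)c4)c3)cc2-c2ccncc2)ccc1Cl` gives 1140 nM, so compound 3 carries the lowest number of the three, although its gaps to compound 2 and to compound 1 both stay within the scatter. Among the measured compounds shown here, the only step between measured compounds, a 1.5-fold lower number from compound 1 to compound 2 (0.19 log units; within the scatter), changes a group on an amide-type nitrogen and does not touch the oxygen where compound 4 differs. For the measured compounds named here, compound 4 `O=C(Nc1cccc(-n2cc(-c3ccncc3)c(-c3ccc(Cl)c(O)c3)n2)c1)Nc1ccc(Cl)c(C(F)(F)F)c1` differs from compound 3 by hydrogen in place of methyl on an oxygen on an aromatic ring; no measured step bears on this change. The step from compound 3 to compound 4 in this assay is therefore expected to be a 1.1-fold higher number from compound 3 to compound 4 (0.02 log units; within the scatter), nothing beyond the scatter. Compound 4 is estimated at 1200 nM, within 500 nM to 2900 nM.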

Compound 4, concentration for 50% growth inhibition: 1120 nM
Beside the measured number, compound 4's estimate is 1.1-fold (0.03 log units) above it, and the stated range covers the measured number.
By their numbers in this assay, from the lowest: compounds 4, 3, 2 and 1 (each within the scatter of the next).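

In this assay, methoxy to hydroxy at this oxygen gives a 1.0-fold lower number from compound 3 to compound 4 (0.01 log units; within the scatter) and so shows that, in this series, methyl and hydrogen on this oxygen cannot be told apart. Two single changes on an aromatic carbon also stay within the scatter: trifluoromethyl in place of chloro gives a 1.2-fold lower number from compound 2 to compound 4 (0.07 log units; within the scatter) and chloro in place of hydrogen gives a 1.8-fold lower number from compound 1 to compound 4 (0.25 log units; within the scatter). Nothing measured here offers an explanation for these results. Still open, as far as these compounds go, is whether a longer chain on this oxygen, or an amine in place of the hydroxy, would stay within the scatter of compound 4.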